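The source may hold more compounds than are shown below. What is called first, only, known or untested is meant among the compounds shown, and "the series" means these compounds.

Working notes on the series, read in an ADME assay on BJ cells (Homo sapiens) for cytotoxicity, with a stated time of 72 h; a higher number here means that more compound is needed for the effect, a lower number that less compound is needed. Compound 1 `C=C[C@@](C)(/C=C/c1ccc(O)cc1)CCCO` gives > 36600 nM, which is a limit of the assay. Compound 2 `C=C[C@@](C)(/C=C/c1ccc(O)cc1)CC/C=C/C(=O)c1ccccc1` gives > 36600 nM, also a limit. Among the measured compounds shown here, compound 3 `COc1ccc(/C=C/[C@@](C)(/C=C/c2ccc(O)c(C=O)c2)CCC=C(C)C)cc1` gives 9800 nM, the only actual number so far. Compound 4 `COc1ccc(/C=C/[C@@](C)(/C=C/c2ccc(O)c(/C=C/C(=O)c3ccccc3)c2)CCC=C(C)C)cc1` is not yet measured. It carries 2-benzoylethenyl in place of formyl on an aromatic carbon, ortho to a hydroxy group: 2-benzoylethenyl in place of formyl on an aromatic carbon. For the measured compounds named here, no step between measured compounds is available as a guide. A modest move towards a lower number in this assay is expected, and the expected change is a 1.4-fold lower number from compound 3 to compound 4 (0.15 log units; within the scatter). For compound 4 the estimated value is 7000 nM, with an expected range of 2500 nM to 20000 nM.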

Compound 4, half-maximal effective concentration: > 36600 nM
Compound 4 was reported as a limit; the forecaster's own chance of this, stated with the estimate: 15%; middle value at least 5.2-fold (0.71 log units) away from the limit.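

In this assay, among the compounds shown here, 2-benzoylethenyl in place of formyl on an aromatic carbon, ortho to a hydroxy group, gives the only readable step: an at least 3.7-fold higher number from compound 3 to compound 4 (0.57 log units; beyond the scatter). The read-out therefore responds to the group at this position, and among the compounds shown, only compound 3, with formyl, gives an actual number. The full size of the step stays unknown, since compound 4 sits at a limit of the assay: the limit of > 36600 nM in this assay, at which 3 of the 4 values shown sit.

The compounds shown do not separate the added benzene ring from the added ethenyl link. From the compounds shown here alone, how a carboxylic acid or an amine at this position would read in this assay also stays open.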